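From propyl to hydroxymethyl on an aromatic nitrogen

The source may hold more compounds than are shown below. What is called first, only, known or untested is meant among the compounds shown, and "the series" means these compounds.

In a functional assay on MKN-45 cells (Homo sapiens) for inhibition, with a stated time of 72 h (a higher number here means a weaker inhibitor, a lower number a stronger inhibitor), compound 1 `COc1cc(C(=O)c2ccc3[nH]ccc3c2)cc(OC)c1OC`, with hydrogen on its aromatic nitrogen, gives 88 nM. Compound 2 `CCn1ccc2cc(C(=O)c3cc(OC)c(OC)c(OC)c3)ccc21`, with ethyl there, gives 31 nM, and compound 3 `CCCn1ccc2cc(C(=O)c3cc(OC)c(OC)c(OC)c3)ccc21`, with propyl there, gives 680 nM. Compound 3 is the weakest of the three, as a 7.7-fold higher number from compound 1 to compound 3 (0.89 log units; beyond the scatter) and a 22-fold higher number from compound 2 to compound 3 (1.34 log units; beyond the scatter) show.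

Compound 4 `COc1cc(C(=O)c2ccc3c(ccn3CO)c2)cc(OC)c1OC` has not yet been measured. It differs from compound 3 by this change: hydroxy in place of ethyl on a saturated chain carbon bound to an aromatic nitrogen. In words, this is hydroxy in place of ethyl on a saturated chain carbon bound to an aromatic nitrogen, so propyl becomes hydroxymethyl.

Among the measured compounds shown here, no measured step makes this exact change, and no measured compound carries a hydroxy group, so the expectation rests on the steps at the same nitrogen. These do not run in one direction: a 2.8-fold lower number from compound 1 to compound 2 (0.45 log units; beyond the scatter) is modest, whereas the step from ethyl to propyl is large. Compound 4 no longer holds the propyl group, and both compounds without it have lower numbers. A large step to a lower number is therefore expected in this assay. The expected change is a 9.7-fold lower number from compound 3 to compound 4 (0.99 log units; beyond the scatter). For compound 4 the estimate is 70 nM, with an expected range from 20 nM to 250 nM.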

Compound 4, half-maximal inhibitory concentration: 33 nM
Estimate against measurement, compound 4: 2.1-fold (0.33 log units) above; low and high end bracket the measured number.
By their numbers in this assay, from the lowest: compounds 2 and 4 (each within the scatter of the next); then compound 1; then compound 3.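

In this assay the high number of the propyl compound does not carry over to hydroxymethyl at this nitrogen: a 21-fold lower number from compound 3 to compound 4 (1.31 log units; beyond the scatter) is a large step, while a 1.1-fold higher number from compound 2 to compound 4 (0.03 log units; within the scatter) lies within the scatter, so hydroxymethyl and ethyl cannot be told apart here. The earlier compounds shown here showed only alkyl groups on this nitrogen, with ethyl giving a lower number than hydrogen and propyl a higher one; compound 4 adds a group bearing hydroxy, and a 2.7-fold lower number from compound 1 to compound 4 (0.43 log units; beyond the scatter) places it on the same side of hydrogen as ethyl. Nothing among the data shown gives a reason for these steps.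

The compounds shown leave open whether the high number of compound 3 belongs to propyl alone or to any longer chain on this nitrogen, and a hydroxyethyl group would speak to that, as it carries hydroxy on a longer chain. They also leave open whether hydroxy is particular in this place, since neither a methoxymethyl group nor an aminomethyl group stands among them.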